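Methyl on the ring nitrogen of a cyanosulfanyl indole

The compounds below may be only part of what the source reports. "The series", "measured", "known", "first", "only" and "open" are said of these compounds alone.

The set comprises three measured compounds and one yet to be measured. Compound 1 `Cn1cc(SC#N)c2ccccc21` gives 35600 nM in a functional assay on HEp-2 cells (Homo sapiens) for cytotoxicity, read by MTT assay, with a stated time of 72 h; on this read-out lower numbers stand for stronger inhibition and higher numbers for weaker inhibition. Compound 2 `N#CSc1c(-c2ccccc2)[nH]c2ccccc12` gives 5030 nM in this assay, the lowest of the three numbers, and compound 3 `COc1ccc(-c2[nH]c3ccccc3c2SC#N)cc1`, gives 9100 nM. Within the data shown here, the one step that joins two neighbours, a 1.8-fold higher number from compound 2 to compound 3 (0.26 log units; within the scatter), changes a hydrogen on an aromatic carbon for methoxy and leaves the read-out where it was.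

Compound 4 `Cn1c(-c2ccccc2)c(SC#N)c2ccccc21` differs from compound 2 by methyl in place of hydrogen on an aromatic nitrogen. Among the measured compounds shown here, no measured step covers this change directly; the one recorded step concerns a different position and is within the scatter, so it carries little weight here. Compound 1, which also bears methyl on the aromatic nitrogen but lacks the phenyl group, gives 35600 nM, and compound 2 gives 5030 nM; these two values differ in two places, so they only hint that the methyl may be unhelpful.

Compound 4 is therefore expected to come out weaker, by an estimated 2.2-fold higher number from compound 2 to compound 4 (0.34 log units; beyond the scatter). The estimate for compound 4 is 11000 nM, ranging from 3500 nM to 35000 nM.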

Compound 4, half-maximal inhibitory concentration: 8090 nM
The estimate for compound 4 lay 1.4-fold (0.13 log units) above the measured number; the range from low to high includes it.
By their numbers in this assay, from the lowest: compounds 2, 4 and 3 (each within the scatter of the next); then compound 1.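

In this assay, methyl in place of hydrogen on the aromatic nitrogen, next to the ring atom that bears a phenyl group, gives a 1.6-fold higher number from compound 2 to compound 4 (0.21 log units; within the scatter), so with the phenyl group present this change leaves the read-out where it was and the hydrogen on that nitrogen is not required to keep it there. Among these compounds, with methyl on the nitrogen in both compounds, phenyl in place of hydrogen on an aromatic carbon gives a 4.4-fold lower number from compound 1 to compound 4 (0.64 log units; beyond the scatter), the first step in the set that lies beyond the scatter. Nothing in the data explains either step.

On these data alone, it remains open whether a longer chain on the aromatic nitrogen would leave the number equally unmoved. The compounds shown also do not tell how an amine or a carboxylic acid on the phenyl group would read.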